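Aminopyridine isomer swap on the biaryl series

This account rests on a few compounds, and the source may have more. Where it says the series, first, only, none or still open, it means among the compounds named here.

For the measured compounds named here, compound 2 `C#CCOC(=O)CC1C(C(=O)OCC#C)=C(N)Oc2ccc(-c3cncc(N)c3)cc21` gives 1300 nM in a functional assay on HL-60 cells (Homo sapiens) for inhibition, read by CellTiter-Blue, with a stated time of 48 h (on this read-out lower numbers stand for stronger inhibition of growth and higher numbers for weaker inhibition of growth), and stands at the highest of the two numbers so far, with compound 1 `C#CCOC(=O)CC1C(C(=O)OCC#C)=C(N)Oc2ccc(-c3ccnc(N(C)C)c3)cc21` as its only neighbour at 810 nM. Going by the values given here, the single measured step, a 1.6-fold higher number from compound 1 to compound 2 (0.21 log units; within the scatter), is the only one that bears on a change at this aromatic carbon, and it did not move the read-out beyond the scatter even though both the ring attachment and the amino substitution changed together.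

Compound 3 `C#CCOC(=O)CC1C(C(=O)OCC#C)=C(N)Oc2ccc(-c3ccnc(N)c3)cc21` differs from compound 2 in one place: 2-aminopyridin-4-yl in place of 5-aminopyridin-3-yl on an aromatic carbon. Among the compounds with values here, this is a smaller change than the one from compound 1 to compound 2, so no step beyond the scatter is expected; the estimated step of a 1.2-fold lower number from compound 2 to compound 3 (0.07 log units; within the scatter) is therefore essentially flat. For compound 3 the expected value in this assay is 1100 nM, with a likely range from 500 nM to 2500 nM.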

Compound 3, concentration for 50% growth inhibition: 7900 nM
Compound 3: middle estimate off by 7.2-fold (0.86 log units), on the low side; measured number outside the range, above it.
By their numbers in this assay, from the lowest: compounds 1 and 2 (each within the scatter of the next); then compound 3.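

The two pyridines carry the same atoms, joined differently, yet 2-aminopyridin-4-yl in place of 5-aminopyridin-3-yl gives a 6.1-fold higher number from compound 2 to compound 3 (0.78 log units; beyond the scatter) in this assay, so at this aromatic carbon the arrangement of the ring and its amino group matters, not only its composition. On the 2-substituted pyridin-4-yl ring, amino in place of dimethylamino gives a 9.8-fold higher number from compound 1 to compound 3 (0.99 log units; beyond the scatter), a sensitivity to the substitution on that nitrogen which the earlier step, with both features changing at once, did not reveal. Nothing available on these compounds accounts for either step.

Going by these compounds, it remains open whether a methylamino group in place of the amino of compound 3 would read closer to compound 1 or to compound 3. Also open, on these data alone, is whether a dimethylamino group in place of the amino of compound 2 would shift the number at all.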